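This account rests on a few compounds, and the source may have more. Where it says the series, first, only, none or still open, it means among the compounds named here.

Measured compounds:
Compound 1, `O=C1/C(=C/c2ccncc2)CN(S(=O)(=O)c2ccc(Cl)cc2)C/C1=C\c1ccccc1F`: 12500 nM
Compound 2, `O=C1/C(=C/c2ccncc2)CN(S(=O)(=O)c2ccc(Br)cc2)C/C1=C\c1ccccc1F`: 11500 nM
Compound 3, `O=C1/C(=C/c2cccnc2)CN(S(=O)(=O)c2ccc(Cl)cc2)C/C1=C\c1ccccc1C(F)(F)F`: 3440 nM

All three were tested in a functional assay on QGY-7703 cells (Homo sapiens) for cytotoxicity, read by MTT assay, with a stated time of 24 h; a lower number here means a stronger inhibitor, a higher number a weaker inhibitor. Compound 1 and compound 2 share one core and differ only in one spot: bromo in place of chloro on an aromatic carbon. That change made a step of a 1.1-fold lower number from compound 1 to compound 2 (0.04 log units; within the scatter), so the two values are as good as the same. Compound 3 has a different core, and the difference between the two cores is not broken down here; what the values show is that compound 3 sits at a lower number than both compound 1 and compound 2, beyond the usual scatter in each case.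

Compound 4, `O=C1/C(=C/c2cccnc2)CN(S(=O)(=O)c2ccc(Br)cc2)C/C1=C\c1ccccc1C(F)(F)F`, is not yet measured. It relates to compound 3 exactly as compound 2 relates to compound 1: bromo in place of chloro on an aromatic carbon, with the same place described in the same words. The step expected in this assay is a 1.1-fold lower number from compound 3 to compound 4 (0.05 log units; within the scatter), kept small because the same change earlier gave a 1.1-fold lower number from compound 1 to compound 2 (0.04 log units; within the scatter). Compound 4 is therefore expected to give about 3100 nM, with a range from 1500 nM to 6500 nM allowing for the scatter of repeated measurements.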

Compound 4, half-maximal inhibitory concentration: 5510 nM
Compound 4: middle estimate off by 1.8-fold (0.25 log units), on the low side; low and high end bracket the measured number.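

In this assay, putting bromo in place of chloro on the core of compound 3 gave a 1.6-fold higher number from compound 3 to compound 4 (0.20 log units; within the scatter), so this swap leaves the value essentially unchanged here, as it did on the core of compound 1. Set side by side, the two results do not differ by more than repeated measurements would: the same change on two cores in this assay, a 1.1-fold lower number (0.04 log units; within the scatter) from compound 1 to compound 2 and a 1.6-fold higher number (0.20 log units; within the scatter) from compound 3 to compound 4, 1.7-fold (0.24 log units) apart, within the scatter of two such steps. In this series, then, the swap between these two halogens can be carried from one of these cores to the other as a change with no clear effect, but two pairs in one cell assay do not show why that is, or that it would hold on any further core or in another test.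

The compounds shown carry only chloro or bromo in this place, so it remains open whether a quite different group there, such as an amine, a carboxylic acid or a longer chain, would move the number. They also leave open which part of the difference between the two cores goes with the lower numbers of compound 3 and compound 4.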